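This account rests on a few compounds, and the source may have more. Where it says the series, first, only, none or still open, it means among the compounds named here.

Notes on the series. Compound 1 `N#CC1=C(N)Oc2c(c3nc4ccccc4nc3c3ccccc23)C12C(=O)N(Cc1cnnn1-c1ccc(Cl)cc1)c1ccccc12`, compound 2 `N#CC1=C(N)Oc2c(c3nc4ccccc4nc3c3ccccc23)C12C(=O)N(Cc1cnnn1-c1ccc([N+](=O)[O-])cc1)c1ccccc12` and compound 3 `N#CC1=C(N)Oc2c(N)cc3nc4ccccc4nc3c2C12C(=O)N(Cc1cnnn1-c1ccc([N+](=O)[O-])cc1[N+](=O)[O-])c1ccccc12` have been run in an ADME assay on HUVEC cells (Homo sapiens) for antiproliferative activity, read by MTT assay, with a stated time of 48 h; on this read-out higher numbers stand for weaker inhibition and lower numbers for stronger inhibition. For compound 1 the assay returns only a limit, > 50000 nM. For compound 2 the read-out is likewise a limit, > 50000 nM. For compound 3 the result is again a limit, > 50000 nM. Compound 2 and compound 1 differ by chloro in place of nitro on an aromatic carbon; the step that the two limits leave unreadable from compound 2 to compound 1 cannot be read because of the limit of > 50000 nM in this assay, at which 3 of the 3 values shown sit. The difference between the cores of compound 2 and compound 3 is not broken down here. Compound 4 `N#CC1=C(N)Oc2c(N)cc3nc4ccccc4nc3c2C12C(=O)N(Cc1cnnn1-c1ccc(Cl)cc1[N+](=O)[O-])c1ccccc12` is not yet measured; it differs from compound 3 by chloro in place of nitro on an aromatic carbon. The place is not identical: in compound 4 the entering chloro is meta to a nitro group, which is not the case in compound 1, so this is the same kind of change, not the same one. Compound 3 sits at the limit > 50000 nM. On that basis compound 4 is expected to repeat this outcome, with an estimated step of a number no higher from compound 3 to compound 4 (the limit leaves the size open). In this assay compound 4 is estimated at 50000 nM, within 20000 nM to 120000 nM, most likely reported only as a limit.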

Compound 4, half-maximal inhibitory concentration: > 50000 nM
Compound 4 was reported as a limit (the forecaster's own chance of this, stated with the estimate: 85%); the middle value sits exactly at the limit.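

No new step can be read from compound 3 to compound 4 in this assay, because each gives only a limit: the limit of > 50000 nM in this assay, at which 4 of the 4 values shown sit.

The compounds shown leave open whether chloro in place of nitro, or the difference between the cores of compound 2 and compound 3, changes the read-out in this assay at all.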